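Swapping the aryl group on a shared ester core

The source may hold more compounds than are shown below. What is called first, only, known or untested is meant among the compounds shown, and "the series" means these compounds.

Measured compounds:
- compound 1 `CCO/C(O)=C1\C(C)=NC(C)=C(C(=O)OCCCN2C(=O)c3ccccc3S2(=O)=O)C1c1ccccc1[N+](=O)[O-]`: 2.6 nM
- compound 2 `CC1=NC(C)=C(C(=O)OCCCN2C(=O)c3ccccc3S2(=O)=O)C(c2ccccc2[N+](=O)[O-])/C1=C(\O)OC(C)C`: 1.2 nM

In a functional assay (aorta) with Oryctolagus cuniculus as the target (a higher number here means a weaker inhibitor, a lower number a stronger inhibitor), compound 1 gives 2.6 nM. Compound 2 differs from it only by a methyl in place of hydrogen on a saturated chain carbon bound to an oxygen on an unsaturated carbon and a saturated chain carbon, and in this assay compound 2 gives 1.2 nM; the step of a 2.2-fold lower number from compound 1 to compound 2 (0.34 log units; beyond the scatter). Compound 2 thus holds the lowest of the two numbers recorded so far.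

Compound 3 `CC1=NC(C)=C(C(=O)OCCCN2C(=O)c3ccccc3S2(=O)=O)C(c2cccc(Cl)c2Cl)/C1=C(\O)OC(C)C` keeps everything of compound 2 except the change (2,3-dichlorophenyl in place of 2-nitrophenyl on a saturated ring carbon), a 2,3-dichlorophenyl in place of 2-nitrophenyl on a saturated ring carbon. Among the compounds with values here, no measured step touches this ring, so nothing here tells how this assay responds to it; the only measured step concerns the ester chain and does not bear on it. The expectation is therefore no step beyond the scatter, with a wide band of uncertainty, and compound 3 is estimated at 1.2 nM (range 0.25 nM to 6 nM), an expected step of no change at the digits printed from compound 2 to compound 3 (within the scatter).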

Compound 3, half-maximal inhibitory concentration: 2.1 nM
Compound 3: the middle estimate sits 1.8-fold (0.24 log units) below what was measured, and the stated range covers the measured number.
By their numbers in this assay, from the lowest: compounds 2, 3 and 1 (each within the scatter of the next, the first and the last beyond it).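

At this saturated ring carbon, 2,3-dichlorophenyl in place of 2-nitrophenyl gives a 1.8-fold higher number from compound 2 to compound 3 (0.24 log units; within the scatter) in this assay, so this first measured change of the aryl group leaves compound 2 and compound 3 indistinguishable. The entering group has 0 hydrogen-bond acceptors against 2 for the group that leaves, and it has chlorine where the other has nitrogen and oxygen, yet this pair shows no step beyond the scatter. Nothing available explains this result.

Only these two substituted aryl groups are shown at this carbon, so it remains open how an unsubstituted phenyl, a pyridyl ring or a cyclohexyl group would read there. Going by these compounds, it is also open whether the ethyl and isopropyl ester chains would differ in the same way when the ring carries 2,3-dichlorophenyl.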